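Dimethoxyphenyl Variant of a Spirooxindole Triazole Series

The compounds below may be only part of what the source reports. "The series", "measured", "known", "first", "only" and "open" are said of these compounds alone.

Going by the values given here, compound 2 `N#CC1=C(N)Oc2c(N)cc3nc4ccccc4nc3c2C12C(=O)N(Cc1cnnn1-c1cc(Cl)ccc1Cl)c1ccccc12` gives 10900 nM in a functional assay on A549 cells (Homo sapiens) for antiproliferative activity, read by MTT assay, with a stated time of 48 h (a lower number here means a stronger inhibitor, a higher number a weaker inhibitor), the lower of the two numbers measured so far. Among the compounds with values here, compound 1 `COc1ccccc1-n1nncc1CN1C(=O)C2(C(C#N)=C(N)Oc3c(N)cc4nc5ccccc5nc4c32)c2ccccc21` gives 37500 nM in this assay, and the step of a 3.4-fold lower number from compound 1 to compound 2 (0.54 log units; beyond the scatter) is the only one bearing on the change at hand. Compound 3 `COc1ccc(OC)c(-n2nncc2CN2C(=O)C3(C(C#N)=C(N)Oc4c(N)cc5nc6ccccc6nc5c43)c3ccccc32)c1` differs from compound 2 by 2,5-dimethoxyphenyl in place of 2,5-dichlorophenyl on an aromatic nitrogen, which partly returns toward the methoxy pattern of compound 1. A higher number than that of compound 2 is therefore expected, roughly undoing that step. Compound 3 is estimated at 30000 nM, between 12000 nM and 75000 nM, the expected step being a 2.8-fold higher number from compound 2 to compound 3 (0.44 log units; beyond the scatter).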

Compound 3, half-maximal inhibitory concentration: 28100 nM
Compound 3: the middle estimate sits 1.1-fold (0.03 log units) above what was measured; measured number inside the range.
By their numbers in this assay, from the lowest: compound 2; then compounds 3 and 1 (each within the scatter of the next).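

In this assay, 2,5-dimethoxyphenyl in place of 2,5-dichlorophenyl on this aromatic nitrogen gives a 2.6-fold higher number from compound 2 to compound 3 (0.41 log units; beyond the scatter), so the two methoxy groups do not match the two chlorines here. Methoxy in place of hydrogen on an aromatic carbon gives a 1.3-fold lower number from compound 1 to compound 3 (0.13 log units; within the scatter), so the second methoxy makes no readable difference in this assay. No measurement shown accounts for either step. On these data alone, how a phenyl ring carrying an amine or a carboxylic acid would behave on this nitrogen remains open, as does the effect of a single chlorine.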